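This account rests on a few compounds, and the source may have more. Where it says the series, first, only, none or still open, it means among the compounds named here.

The measured compounds and their numbers:

Compound 1, `CS(=O)(=O)c1ccc(-c2cnc3[nH]cc(-c4nnc(-c5ccc(Cl)cc5)o4)c(=O)c3c2)cc1`, gives 1.64%.
Compound 2, `Cc1ccc(-c2nnc(-c3c[nH]c4ncc(-c5ccc(S(C)(=O)=O)cc5)cc4c3=O)o2)cc1`, gives 18.5%.
Compound 3, `N#Cc1ccc(-c2cnc3[nH]cc(-c4nnc(-c5ccc(Cl)cc5)o4)c(=O)c3c2)cc1`, gives 13.7%.

All three were tested in a functional assay on HeLa cells (Homo sapiens) for inhibition, read by MTT assay, with a stated time of 24 h, tested at 10 uM; on this read-out higher numbers stand for more inhibition of growth at the one concentration tested and lower numbers for less inhibition of growth. Compound 3 stands second highest of the three numbers; its nearest neighbour is compound 2, a gap that lies within the scatter, while compound 1 sits beyond the scatter below it.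

Compound 4, `O=c1c(-c2nnc(-c3ccc(Cl)cc3)o2)c[nH]c2ncc(-c3ccccc3)cc12`, has not yet been measured. It differs from compound 3 in one place: hydrogen in place of cyano on an aromatic carbon. Cut one bond further out, the 4-cyanophenyl group becomes a plain phenyl, on the ring that sits para to a large group.

Going by the values given here, only one measured step touches this same position: a number 12.1 percentage points higher from compound 1 to compound 3 (beyond the scatter), a modest change when cyano replaced methylsulfonyl. The other step, a number 16.9 percentage points higher from compound 1 to compound 2 (beyond the scatter), concerns a different ring and says nothing direct about this site. Since a swap at this position moved the number only modestly, the expectation for compound 4 is a small step, not clearly beyond the scatter, and if anything downward: a number 4.7 percentage points lower from compound 3 to compound 4 (within the scatter). Compound 4 is therefore estimated at 9%, with a range from 0% to 24%.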

Compound 4, percent growth inhibition at one concentration: 31.3%
Estimate against measurement, compound 4: 22.3 percentage points below; the measured number lies above the stated range.
By their numbers in this assay, from the lowest: compound 1; then compounds 3 and 2 (each within the scatter of the next); then compound 4.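

In this assay, taking away the cyano group so that the 4-cyanophenyl becomes a plain phenyl gives a number 17.6 percentage points higher from compound 3 to compound 4 (beyond the scatter). Replacing methylsulfonyl with hydrogen on the same aromatic carbon gives a number 29.7 percentage points higher from compound 1 to compound 4 (beyond the scatter). The earlier step only compared two substituents with each other, whereas these steps add the unsubstituted phenyl as a reference, and both substituted compounds lie beyond the scatter below it; nothing available here accounts for this difference.

On these data alone, it remains open whether any substituent on this carbon lowers the number or only cyano and methylsulfonyl do, a question that an amine, a methoxy group or a carboxylic acid at the same place could help to answer. As far as these compounds go, it is also open whether the plain phenyl would keep its higher number with methyl in place of chloro on the other aromatic ring, and how the number would change at other concentrations, since each compound here has a reading at just one.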